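The source may report more compounds than this note shows. Statements on the series, on what has been measured and on what is new or still open speak of the compounds shown alone.

Compound 1 `C=CCn1c(=O)/c(=C\c2cc(Br)ccc2F)[nH]c(=O)/c1=C\c1ccccc1OC` gives 5100 nM in a functional assay on K562 cells (Homo sapiens) for cytotoxicity, read by CCK-8 assay, with a stated time of 72 h; a lower number here means a stronger inhibitor, a higher number a weaker inhibitor. For the measured compounds named here, of the two compounds measured so far, compound 1 has the higher number. The other one, compound 2 `COc1ccccc1/C=c1\c(=O)[nH]/c(=C/c2cccc(Cl)c2Cl)c(=O)n1C`, gives 110 nM in this assay, a lower number by a margin beyond the usual scatter, so compound 2 is the stronger inhibitor of the pair. Compound 2 differs from compound 1 in more than one place, so the two do not form a single step.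

Compound 3 `C=CCn1c(=O)/c(=C\c2ccccc2F)[nH]c(=O)/c1=C\c1ccccc1OC` has not been measured. It differs from compound 1 in one place only: hydrogen in place of bromo on an aromatic carbon. Going by the values given here, no measured pair shows this change on its own, so there is no measured step to lean on. The change removes one heavy atom and nothing enters but a hydrogen atom, so the expected step from compound 1 to compound 3 in this assay is a 1.8-fold higher number from compound 1 to compound 3 (0.25 log units; within the scatter), a modest move toward a weaker inhibitor that may not exceed the scatter. Compound 3 is therefore estimated at 9000 nM in this assay, with a likely range from 3000 nM to 30000 nM.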

Compound 3, half-maximal inhibitory concentration: 5600 nM
Beside the measured number, compound 3's estimate is 1.6-fold (0.21 log units) above it; low and high end bracket the measured number.
By their numbers in this assay, from the lowest: compound 2; then compounds 1 and 3 (each within the scatter of the next).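

For the compounds shown here, replacing the bromo group with hydrogen, which turns 5-bromo-2-fluorophenyl into 2-fluorophenyl, gives a 1.1-fold higher number from compound 1 to compound 3 (0.04 log units; within the scatter) in this assay and is the first measured view of this position on its own. On the core of compound 1, then, this aromatic carbon can carry either bromo or hydrogen with the two numbers staying within the usual scatter of each other, so the presence of the bromo group cannot be told from its absence in this cytotoxicity read-out. No supporting measurement is available to explain this result.

The compounds shown leave open whether a different group on this same aromatic carbon, such as an amine, a carboxylic acid or a longer chain, would give a number that stands clearly apart from those of bromo and hydrogen. Going by these compounds alone, they also leave open whether hydrogen in place of bromo gives an equally small step on other parts of the series: this single pair is the only measured example of the change.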